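Swapping the 4-hydroxyphenyl group of compound 3

The compounds below may be only part of what the source reports. "The series", "measured", "known", "first", "only" and "open" are said of these compounds alone.

In a functional assay on HL-60 cells (Homo sapiens) for cytotoxicity, read by WST assay, with a stated time of 48 h (a higher number here means that more compound is needed for the effect, a lower number that less compound is needed), compound 1 (`COc1ccccc1C[C@H]1COC(=O)[C@@H]1Cc1ccc(Cl)c(Cl)c1`) gives 14000 nM and compound 2 (`O=C1OC[C@H](Cc2ccccc2F)[C@H]1Cc1ccc(Cl)c(Cl)c1`) gives 28000 nM while compound 3 (`O=C1OC[C@H](Cc2ccc(O)cc2)[C@H]1Cc1ccc(Cl)c(Cl)c1`) gives 37000 nM on the same core. One step here lies within the scatter (a 1.3-fold higher number from compound 2 to compound 3 (0.12 log units; within the scatter)) and another lies beyond it (a 2.6-fold higher number from compound 1 to compound 3 (0.42 log units; beyond the scatter)). Compound 4 (`O=C1OC[C@H](Cc2ccc(F)c(F)c2)[C@H]1Cc1ccc(Cl)c(Cl)c1`) carries 3,4-difluorophenyl in place of 4-hydroxyphenyl (3,4-difluorophenyl in place of 4-hydroxyphenyl on a saturated chain carbon bound to a saturated ring carbon). Within the data shown here, no measured compound holds this group. The nearest guide is compound 2, which also bears fluoro and gives 28000 nM in this assay as its value. The other step among these compounds is also small (a 2.0-fold higher number from compound 1 to compound 2 (0.30 log units; within the scatter)). A step within the scatter, towards a lower number, is therefore expected (a 1.5-fold lower number from compound 3 to compound 4 (0.19 log units; within the scatter)). Compound 4 is estimated at 24000 nM with an expected range from 11000 nM to 50000 nM in this read-out.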

Compound 4, half-maximal effective concentration: 25000 nM
Compound 4: middle estimate off by 1.0-fold (0.02 log units), on the low side; the range from low to high includes it.
By their numbers in this assay, from the lowest: compounds 1, 4, 2 and 3 (each within the scatter of the next, the first and the last beyond it).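

The 3,4-difluorophenyl group, with 0 hydrogen-bond donors and 0 hydrogen-bond acceptors, replaces 4-hydroxyphenyl at this position with a step that stays within the scatter (a 1.5-fold lower number from compound 3 to compound 4 (0.17 log units; within the scatter)). Compound 4 also lies within the scatter of both other compounds (a 1.1-fold lower number from compound 2 to compound 4 (0.05 log units; within the scatter); a 1.8-fold higher number from compound 1 to compound 4 (0.25 log units; within the scatter)), so this change does not reproduce the step beyond the scatter seen between compound 1 and compound 3. No available evidence bears on the cause of these small steps. The compounds shown leave open whether an amine, a carboxylic acid or a longer chain at this place would give a step beyond the scatter.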